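Hydroxy in place of methoxy on a shared lactone core

A few compounds are considered here, and "the series" means these few. Any claim that something is new, unique, unknown or untested is made for them only; others in the source may bear on it.

Of the compounds shown here, two from this series have been tested in a functional assay on HaCaT cells (Homo sapiens) for cytotoxicity, read by MTT assay, with a stated time of 24 h; a lower number here means a stronger inhibitor, a higher number a weaker inhibitor. Compound 1, with the structure `C=C1C(=O)O[C@H](C2=C(C)C(O)CC2=O)[C@@H]1CCC(C)=O`, gives 19.1 ug/mL. Compound 2, with the structure `C=C1C(=O)O[C@H](C2=C(C)[C@@H](OC)CC2=O)[C@@H]1CCC(C)=O`, gives 7.1 ug/mL. Compound 2 therefore has the lowest number of the two, and its gap to compound 1 lies beyond the usual scatter of the method.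

The next compound, compound 3, with the structure `C=C1C(=O)O[C@H](C2=C(C)[C@@H](O)CC2=O)[C@@H]1CCC(C)=O`, has not yet been measured in this assay. It differs from compound 2 in one place: hydrogen in place of methyl on an oxygen on a saturated carbon. Cut one bond further out, the change reads methoxy to hydroxy.

No measured step of this exact kind is available, so the expectation rests on the two numbers shown. Since compound 1 gives 19.1 ug/mL, and compound 1 also carries a hydroxy group, a move toward a higher, weaker number is expected for compound 3, with an estimated step of a 2.0-fold higher number from compound 2 to compound 3 (0.29 log units; within the scatter). Compound 3 is accordingly expected to give about 14 ug/mL, within a range from 6 ug/mL to 32 ug/mL.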

Compound 3, half-maximal inhibitory concentration: 13 ug/mL
Beside the measured number, compound 3's estimate is 1.1-fold (0.03 log units) above it, within the range that was stated.
By their numbers in this assay, from the lowest: compounds 2, 3 and 1 (each within the scatter of the next, the first and the last beyond it).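

In this assay, replacing methoxy with hydroxy on this saturated ring carbon gives a 1.8-fold higher number from compound 2 to compound 3 (0.26 log units; within the scatter). This step stays within the scatter, so removing the methyl from that oxygen produces no change that this assay can distinguish from repeat-measurement noise. The stereo comparison gives a 1.5-fold lower number from compound 1 to compound 3 (0.17 log units; within the scatter), also within the scatter, so a hydroxy compound with this centre drawn as S cannot be told apart from one with no configuration drawn there, and the only structural difference in that pair is this: the fact that one of compounds 1 and 3 is drawn with a defined configuration and the other without, at the place where they differ

The compounds shown leave open whether a larger group on that oxygen, such as ethoxy or benzyloxy, or an amine in place of the oxygen, would shift the number beyond the scatter. They also leave open how a compound with the hydroxy group drawn in the opposite, R configuration at this carbon would compare with the S form, which is the direct test of whether the spatial arrangement at this centre matters in this assay.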